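Swapping Methyl for Chloro in a Weak Compound

The source may report more compounds than this note shows. Statements on the series, on what has been measured and on what is new or still open speak of the compounds shown alone.

Compound 1 `COc1ccc(/C=C2/c3cc(OC)cc(OC)c3[C@@H](c3ccc(OC)cc3)[C@@H]2c2cc(OC)cc(OC)c2)cc1`: 6260 nM
Compound 2 `COc1ccc(/C=C2/c3cc(OC)cc(OC)c3[C@@H](c3ccccc3)[C@@H]2c2cc(OC)cc(OC)c2)cc1`: > 200000 nM
Compound 3 `COc1ccc([C@@H]2c3c(OC)cc(OC)cc3/C(=C/c3ccc(C)cc3)[C@H]2c2cc(OC)cc(OC)c2)cc1`: > 200000 nM

In a functional assay on RAW264.7 cells (Mus musculus) for inhibition, with stated times of 2 h and 24 h (on this read-out higher numbers stand for weaker inhibition and lower numbers for stronger inhibition), compound 3 gives only a limit, > 200000 nM, not a true number. It stands at the limit of > 200000 nM in this assay, at which 2 of the 3 values shown sit. Compound 4 `COc1ccc([C@@H]2c3c(OC)cc(OC)cc3/C(=C/c3ccc(Cl)cc3)[C@H]2c2cc(OC)cc(OC)c2)cc1` has not yet been measured and carries chloro in place of methyl on an aromatic carbon, para to a large group (chloro in place of methyl on an aromatic carbon). Going by the values given here, two measured steps bear on this change, and both are large and beyond the scatter: an at least 31-fold higher number from compound 1 to compound 2 (1.50 log units; beyond the scatter) and an at least 31-fold higher number from compound 1 to compound 3 (1.50 log units; beyond the scatter). Neither step tests chloro, but chloro does not restore the methoxy lost in an at least 31-fold higher number from compound 1 to compound 3 (1.50 log units; beyond the scatter), so at most a modest move towards stronger inhibition is expected. The expected size of the change is an at least 2.0-fold lower number from compound 3 to compound 4 (0.30 log units; that floor lies within the scatter). Compound 4 is estimated at 100000 nM, with an expected range of 10000 nM to 200000 nM.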

Compound 4, half-maximal inhibitory concentration: > 200000 nM
Compound 4: no number, only a limit; the forecaster's own chance of this, stated with the estimate: 60%; middle value at least 2.0-fold (0.30 log units) from the limit.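

Chloro in place of the methoxy of compound 1 brings an at least 31-fold higher number from compound 1 to compound 4 (1.50 log units; beyond the scatter), so hydrogen, methyl and chloro at this position all give a large loss of inhibition. The step from compound 3 to compound 4 cannot be read, since both values are limits, and methyl and chloro cannot be ranked. Only compound 1 gives a true number in this assay, and the others share one limit: the limit of > 200000 nM in this assay, at which 3 of the 4 values shown sit.

Going by these compounds, whether a group other than methoxy can keep inhibition at this position stays open. Ethoxy, hydroxyl or an amine would each test this.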